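Series notes: aryl swap on the tetrazole of compound 2

This account rests on a few compounds, and the source may have more. Where it says the series, first, only, none or still open, it means among the compounds named here.

Among the compounds with values here, compound 2 `COc1ccc(-c2nnn(CC(=O)Nc3cc(C)nn3C3CCCCC3)n2)cc1` gives 175 nM in an assay on HEK293 cells for activation of Kir3.1/Kir3.2 (Homo sapiens), read by thallium flux (a higher number here means that more compound is needed for the effect, a lower number that less compound is needed), and holds the lowest of the two numbers so far; compound 1 `Cc1cc(NC(=O)Cn2nnc(-c3cccnc3)n2)n(C2CCCCC2)n1` gives 1930 nM in this assay. Within the data shown here, the one measured step, an 11-fold lower number from compound 1 to compound 2 (1.04 log units; beyond the scatter), shows that the aryl group on the five-membered ring with 4 nitrogen moves the number strongly. Compound 3 `Cc1cc(NC(=O)Cn2nnc(-c3cccc(C(F)(F)F)c3)n2)n(C2CCCCC2)n1` carries the change (3-(trifluoromethyl)phenyl in place of 4-methoxyphenyl on an aromatic carbon). Among the measured compounds shown here, no measured step covers this exact exchange; the direction is open, and a step of middling size either way is possible. Compound 3 is expected to give 400 nM (range 120 nM to 1500 nM), an estimated step of a 2.3-fold higher number from compound 2 to compound 3 (0.36 log units; beyond the scatter).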

Compound 3, half-maximal effective concentration: 183 nM
Compound 3: middle estimate off by 2.2-fold (0.34 log units), on the high side, within the range that was stated.
By their numbers in this assay, from the lowest: compounds 2 and 3 (each within the scatter of the next); then compound 1.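

The exchange of 4-methoxyphenyl for 3-(trifluoromethyl)phenyl on this aromatic carbon gives a 1.0-fold higher number from compound 2 to compound 3 (0.02 log units; within the scatter) and leaves the two groups level. Putting 3-(trifluoromethyl)phenyl in place of pyridin-3-yl gives an 11-fold lower number from compound 1 to compound 3 (1.02 log units; beyond the scatter) as well, so the large step seen earlier is not particular to 4-methoxyphenyl. Nothing on hand accounts for either step.

Open, going by these compounds, is whether unsubstituted phenyl, 4-chlorophenyl or piperidin-4-yl on this carbon would stay level with compound 2 and compound 3 or give a number closer to that of compound 1.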